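Swapping a Methyl Ester Phenyl for a Dihydroxyphenyl

The source may report more compounds than this note shows. Statements on the series, on what has been measured and on what is new or still open speak of the compounds shown alone.

Measured so far:
- compound 1 `COC(=O)c1ccc(/C=N/NC(=O)c2ccc(-c3nc4ccccc4s3)cc2)cc1`: "not active" (no number reported)
- compound 2 `COc1ccc(/C=N/NC(=O)c2ccc(-c3nc4ccccc4s3)cc2)cc1OC`: "not active" (no number reported)
- compound 3 `O=C(N/N=C/c1ccc([N+](=O)[O-])cc1)c1ccc(-c2nc3ccccc3s2)cc1`: 26400 nM

Of the compounds shown here, three sharing one core have been tested in an assay on isolated protein for inhibition of Maltase-glucoamylase (Homo sapiens), with a stated time of 15 min; on this read-out lower numbers stand for stronger inhibition and higher numbers for weaker inhibition. Compound 1 is reported as "not active" (no number reported), with no number attached. Compound 2 is likewise reported as "not active" (no number reported). Only compound 3 carries a figure: in this assay compound 3 gives 26400 nM, a weak result. So compound 1 stands at the inactive end of this small set, and no step between any two of these compounds is available.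

Compound 4 `O=C(N/N=C/c1cc(O)ccc1O)c1ccc(-c2nc3ccccc3s2)cc1` is not yet measured. It differs from compound 1 in a single place: 2,5-dihydroxyphenyl in place of 4-(methoxycarbonyl)phenyl on a carbon with a double bond to nitrogen. Two hydroxyl groups replace an ester on the ring attached to the carbon with a double bond to nitrogen.

Compound 1 carries no number. Within the data shown here, no step in this assay can be sized, and the direction of any change rests only on the weak figure of compound 3 and the silence of compounds 1 and 2. An improvement into measurable but still weak territory is the expectation, though a report of no activity remains quite possible. Compound 4 is expected to give about 15000 nM, within a range of 3000 nM to 60000 nM.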

Compound 4, half-maximal inhibitory concentration: 11900 nM
Compound 4: middle estimate off by 1.3-fold (0.10 log units), on the high side; the range from low to high includes it.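

In this assay, the group on the carbon with a double bond to nitrogen now has a step that can be sized: placing 2,5-dihydroxyphenyl in place of 4-nitrophenyl gives a 2.2-fold lower number from compound 3 to compound 4 (0.35 log units; beyond the scatter), so a change at this one position moves the read-out while the shared core stays the same. Compound 4 also gives a number where compound 1, with its 4-(methoxycarbonyl)phenyl, is reported as "not active" (no number reported) and compound 2 is reported as "not active" (no number reported), but the steps to these two compounds cannot be read, since neither carries a figure. No measurement here accounts for the difference between the groups at this position.

Even so, compound 4 stays weak at 11900 nM, and the compounds shown cannot tell whether both hydroxyl groups are needed for this result or whether one alone would give the same value. Going by these compounds, it also remains open how the read-out would respond to an amine or a carboxylic acid on this ring.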